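The source may report more compounds than this note shows. Statements on the series, on what has been measured and on what is new or still open speak of the compounds shown alone.

Measured in a functional assay on HeLa cells (Homo sapiens) for cytotoxicity, read by XTT assay, with a stated time of 24 h; a higher number here means a weaker inhibitor, a lower number a stronger inhibitor:
Compound 1 `COc1cc(C)c(Cl)c2c1C(=O)C=CC2=O`: 19100 nM
Compound 2 `Cc1cc(O)c2c(c1Cl)C(=O)C=CC2=O`: 13500 nM

Only these two compounds have been measured so far, and they lie within the scatter of each other. In this assay, compound 2 gives 13500 nM, so its number sits level with that of compound 1 and neither can be ranked above the other.

The next compound is compound 3 `CCOc1cc(C)c(Cl)c2c1C(=O)C=CC2=O`. Its structure departs from that of compound 2 by ethyl in place of hydrogen on an oxygen on an aromatic ring, which turns hydroxy into ethoxy, with ethyl in place of hydrogen on an oxygen on an aromatic ring.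

Among the compounds with values here, one measured step bears on this change, since it concerns the same oxygen: a 1.4-fold lower number from compound 1 to compound 2 (0.15 log units; within the scatter). Swapping hydrogen and methyl there moved the number by no more than the scatter. Ethyl is a different group from methyl and has not itself been measured, so this evidence is thin. On that single step, no change beyond the scatter is expected in this assay, and any drift would most likely be towards a slightly higher number.

The expected step is a 1.3-fold higher number from compound 2 to compound 3 (0.10 log units; within the scatter). For compound 3 the estimated value is 17000 nM, with an expected range from 7000 nM to 40000 nM.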

Compound 3, half-maximal inhibitory concentration: 19000 nM
Estimate against measurement, compound 3: 1.1-fold (0.05 log units) below; the measured number falls inside the stated range.
By their numbers in this assay, from the lowest: compounds 2, 3 and 1 (each within the scatter of the next).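

With ethyl on the oxygen on an aromatic ring, the series in this assay now covers hydrogen, methyl and ethyl at this one place, and going from hydroxy to ethoxy gives a 1.4-fold higher number from compound 2 to compound 3 (0.15 log units; within the scatter). The comparison between the two ethers, methyl in place of hydrogen on a saturated chain carbon bound to an oxygen on an aromatic ring, gives a 1.0-fold lower number from compound 1 to compound 3 (0.00 log units; within the scatter), so the assay does not separate compound 1, compound 2 and compound 3, and the earlier finding for methyl also holds for ethyl. Nothing at hand accounts for this flat result or says what the group on this oxygen does in these cells.

The compounds shown leave open whether a longer chain such as butyl, a benzyl group, or a chain ending in an amine or a carboxylic acid on this oxygen would move the number beyond the scatter. All three compounds also share the rest of the core, so they say nothing about how a change elsewhere on it would read in this assay.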